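The compounds below may be only part of what the source reports. "The series", "measured", "known", "first", "only" and "open" are said of these compounds alone.

Working notes on the series. Compound 1 `Oc1ccc(/C=C/CC[C@@H](O)CCc2ccc(O)cc2)cc1` and compound 2 `O=C(CC/C=C/c1ccc(O)cc1)CCc1ccc(O)cc1` share a chain carrying two hydroxyphenyl ends; compound 2 carries a ketone where compound 1 carries a secondary alcohol. In a functional assay on RAW264.7 cells (Mus musculus) for inhibition, read by MTT assay (on this read-out lower numbers stand for stronger inhibition and higher numbers for weaker inhibition), compound 1 gives 16100 nM and compound 2 gives 8930 nM. Among the compounds with values here, compound 2 holds the lower of the two numbers measured so far, but its gap to compound 1 lies within the scatter, so the two read alike on this measure.

The next member is compound 3 `O=C(CC/C=C/c1ccccc1)CCc1ccc(O)cc1`. Relative to compound 2 it differs at one place: hydrogen in place of hydroxy on an aromatic carbon The hydroxy that leaves sits para to a large group on one of the two aromatic rings; the other hydroxyphenyl end is kept.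

Within the data shown here, no measured pair in the set shows what removing one such hydroxy does here, so the expected size of the step rests on the change alone. A modest step toward a higher number, at the edge of the scatter, is expected: a 1.5-fold higher number from compound 2 to compound 3 (0.16 log units; within the scatter). In this assay compound 3 is therefore estimated at 13000 nM, with a range from 5000 nM to 32000 nM.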

Compound 3, half-maximal inhibitory concentration: 6980 nM
For compound 3 the middle estimate is 1.9-fold (0.27 log units) above the measured one, within the range that was stated.
By their numbers in this assay, from the lowest: compounds 3, 2 and 1 (each within the scatter of the next, the first and the last beyond it).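

In this assay, the change from 4-hydroxyphenyl to phenyl gives a 1.3-fold lower number from compound 2 to compound 3 (0.11 log units; within the scatter) and so leaves the read-out within the scatter, which means compound 2 and compound 3 read alike on this measure. Within the data shown here, this is the first direct reading at this position, and it shows that, with the other hydroxyphenyl end kept, the hydroxy on this aromatic carbon can be replaced by hydrogen with no change that this read-out can separate from the scatter; the finding rests on this single pair. No measurement available here bears on why the step is so small.

Going by these compounds, all three compounds keep the other 4-hydroxyphenyl end, so what that end contributes remains open, as does the result of replacing its hydroxy with hydrogen while the first ring stays phenyl. Also open, on these data alone, is whether a methoxy group, a fluorine atom or an amine in the position vacated on the phenyl ring, or a longer chain between the two rings, would move the number beyond the scatter.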